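Methoxy replacing dimethylcarbamoyl on the shared core

This account rests on a few compounds, and the source may have more. Where it says the series, first, only, none or still open, it means among the compounds named here.

Measured so far:
compound 1 `O=C(CCCCCCc1ccccc1)c1nc(Cl)co1` gives 4 nM in an assay on isolated protein for inhibition of Fatty-acid amide hydrolase 1 (Rattus norvegicus); on this read-out lower numbers stand for stronger inhibition and higher numbers for weaker inhibition
compound 2 `CN(C)C(=O)c1coc(C(=O)CCCCCCc2ccccc2)n1` gives 35 nM in this assay

Compound 2 holds the highest of the two numbers in this assay; its nearest neighbour is compound 1, reached by the step of an 8.8-fold higher number from compound 1 to compound 2 (0.94 log units; beyond the scatter), which swaps chloro for dimethylcarbamoyl on an aromatic carbon of the shared core.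

Compound 3 `COc1coc(C(=O)CCCCCCc2ccccc2)n1` is the next variant: methoxy in place of dimethylcarbamoyl on an aromatic carbon, on an aromatic carbon of the five-membered ring, next to the ring nitrogen. For the measured compounds named here, the only measured step touching this position is an 8.8-fold higher number from compound 1 to compound 2 (0.94 log units; beyond the scatter); it changes a different group and gives no direct read on methoxy. With that single reference, no step beyond the scatter is firmly expected in this assay, and a wide range is kept.

Compound 3 is expected at 30 nM in this assay, within 8 nM to 120 nM, a step of a 1.2-fold lower number from compound 2 to compound 3 (0.07 log units; within the scatter).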

Compound 3, inhibition constant: 740 nM
Compound 3: middle estimate off by 25-fold (1.39 log units), on the low side; measured number outside the range, above it.
By their numbers in this assay, from the lowest: compound 1; then compound 2; then compound 3.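

In this assay this position proves highly sensitive to the group it carries: methoxy gives a 21-fold higher number from compound 2 to compound 3 (1.33 log units; beyond the scatter) and, against chloro, a 190-fold higher number from compound 1 to compound 3 (2.27 log units; beyond the scatter), so the loss with methoxy exceeds the one first seen with dimethylcarbamoyl. Dimethylcarbamoyl and methoxy have the same counts of hydrogen-bond donors and acceptors and no net charge, so these counts do not separate them, while the heavy-atom count falls from five to two. No measurement on hand explains either step.

As far as these compounds go, whether the loss follows the oxygen joined directly to the aromatic carbon or the smaller size of methoxy remains open, and an amine, a carboxylic acid or a methyl ester at this position would help separate the two. From the compounds shown here alone, whether the same order holds with a shorter chain on the ketone also remains open.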